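This account rests on a few compounds, and the source may have more. Where it says the series, first, only, none or still open, it means among the compounds named here.

Measured compounds in an ADME assay on a cell-free system (plasma, Homo sapiens) for metabolic stability, with Plasma (Rattus norvegicus) as the target, read by HPLC, at pH 7.4; a lower number here means that the compound disappears faster, a higher number that the compound lasts longer:
Compound 1, `CC(=O)Oc1ccccc1C(=O)O[C@H]1CO[C@H]2[C@@H]1OC[C@H]2OC(=O)C1CC1`, gives 0.015 h.
Compound 2, `COc1cccc(C(=O)O[C@@H]2CO[C@H]3[C@@H]2OC[C@@H]3OC(=O)c2ccccc2OC(C)=O)c1`, gives 0.0142 h.
Compound 3, `COc1ccc(C(=O)O[C@@H]2CO[C@H]3[C@@H]2OC[C@@H]3OC(=O)c2ccccc2OC(C)=O)cc1`, gives 0.0183 h.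

All three numbers lie close together. Compound 3 is separated from neither of the others beyond the scatter: the step of a 1.2-fold higher number from compound 1 to compound 3 (0.09 log units; within the scatter) and the step of a 1.3-fold higher number from compound 2 to compound 3 (0.11 log units; within the scatter) are both small, as is a 1.1-fold lower number from compound 1 to compound 2 (0.02 log units; within the scatter). Within this set, changing the group on the carbonyl carbon from cyclopropyl to 3-methoxyphenyl or 4-methoxyphenyl, or moving the methoxy between those two positions, left the half-life where it was.

Compound 4, `CC(=O)Oc1ccccc1C(=O)O[C@H]1CO[C@H]2[C@@H]1OC[C@H]2OC(=O)c1ccc(-c2ccccc2)cc1`, keeps the core of compound 3 and differs in one place: phenyl in place of methoxy on an aromatic carbon. Among the compounds with values here, no measured step replaces a methoxy by a phenyl, so the expectation rests on the three steps above, none of which moved the number beyond the scatter. The step from compound 3 to compound 4 is therefore expected to be a 1.0-fold lower number from compound 3 to compound 4 (0.01 log units; within the scatter), with no direction beyond the scatter. For compound 4 the half-life in this assay is estimated at 0.018 h, with a range from 0.009 h to 0.036 h.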

Compound 4, half-life: > 0.333 h
Compound 4 was reported as a limit; the forecaster's own chance of this, stated with the estimate: 5%; middle value at least 18-fold (1.26 log units) from the limit.
By their numbers in this assay, from the lowest: compounds 2, 1 and 3 (each within the scatter of the next). At a limit, above all of these: compound 4.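

In this assay, the group on this carbonyl carbon is not indifferent after all: 4-phenylphenyl separates compound 4 from each earlier compound, with an at least 18-fold higher number from compound 3 to compound 4 (1.25 log units; beyond the scatter), an at least 23-fold higher number from compound 2 to compound 4 (1.37 log units; beyond the scatter) and an at least 22-fold higher number from compound 1 to compound 4 (1.34 log units; beyond the scatter). Cyclopropyl, 3-methoxyphenyl and 4-methoxyphenyl gave no separation beyond the scatter, so the shift appears only with phenyl in place of methoxy on the aromatic carbon, and it rests on compound 4 alone. The value of compound 4 is a limit, not a number: the limit of > 0.333 h in this assay, at which 1 of the 4 values shown sits.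

Still open, as far as these compounds go, is whether the shift is specific to the phenyl, which a cyclohexyl, an amine or a carboxylic acid at the same aromatic carbon would test. Also open, from the compounds shown here alone, is how far the half-life of compound 4 lies from its limit.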